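The compounds below may be only part of what the source reports. "The series", "measured", "known", "first", "only" and "open" are said of these compounds alone.

In a functional assay on KB cells (Homo sapiens) for inhibition, read by MTT assay, with a stated time of 24 h, tested at 1 ug/mL (a higher number here means more inhibition of growth at the concentration tested, a lower number less inhibition of growth), compound 1 `O=C(CCCCC1CCSS1)Nc1ccc(Cl)cn1` gives 0.76% and compound 2 `O=C(CCCCC1CCSS1)Nc1cccc2ccccc12` gives 8.37% so the two values lie within the usual scatter of each other. Compound 3 `O=C(CCCCC(S)CCS)Nc1cccc2ccccc12` differs from compound 2 in one place, on a saturated chain carbon, four bonds along the chain from a carbonyl carbon, where the ring gives way to 1,3-disulfanylpropyl: a group of 5 heavy atoms (3 carbon, 2 sulfur; no ring) in place of a group of 5 heavy atoms (3 carbon, 2 sulfur; one five-membered non-aromatic ring with 2 hetero atoms), on a saturated chain carbon, four bonds along the chain from a carbonyl carbon is the whole change. Among the compounds with values here, no measured pair shows a change of this kind, so the data give no size for it, and the expected step of a number 2.6 percentage points higher from compound 2 to compound 3 (within the scatter) is estimated to stay within the scatter. For compound 3 the expected value is 11% with an estimated range from 0% to 30% for growth inhibition.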

Compound 3, percent growth inhibition at one concentration: "not active" (no number reported)
No number was reported for compound 3; there is nothing to compare the estimate with.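

Within the data shown here, compound 3 has no reported number, only "not active", and no step from compound 2 to compound 3 can be read. Nothing measured here accounts for this result. From the compounds shown here alone, how far replacing the ring with 1,3-disulfanylpropyl shifts growth inhibition in this assay stays open.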